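Benzylamino Replaces Cyanopiperidine: Expected Kinetic Solubility

The source may hold more compounds than are shown below. What is called first, only, known or untested is meant among the compounds shown, and "the series" means these compounds.

Compound 1 `COc1cc(Nc2nc(C)cc(N(C)C)n2)ccc1F` in a physicochemical assay for solubility, read by nephelometry, measured as kinetic solubility (on this read-out lower numbers stand for lower solubility and higher numbers for higher solubility), gives only a limit, > 250000 nM.
Compound 2 `COc1cc(Nc2nc(C)cc(N3CCCCC3)n2)ccc1F` in this assay gives 160000 nM.
Compound 3 `COc1cc(Nc2nc(C)cc(N3CCCC(C#N)C3)n2)ccc1F` in this assay gives 219000 nM.

Compound 3 holds the highest of the two numbers; compound 2 is nearest, and that gap, a 1.4-fold higher number from compound 2 to compound 3 (0.14 log units; within the scatter), lies within the scatter. Compound 1 sits at a limit (the limit of > 250000 nM in this assay, at which 1 of the 3 values shown sits).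

Compound 4 `COc1cc(Nc2nc(C)cc(NCc3ccccc3)n2)ccc1F` differs from compound 3 by benzylamino in place of 3-cyanopiperidin-1-yl on an aromatic carbon. The measured steps that exchange the group on this carbon are an at least 1.5-fold lower number from compound 1 to compound 2 (0.19 log units; that floor lies within the scatter) and an at least 1.1-fold lower number from compound 1 to compound 3 (0.05 log units; that floor lies within the scatter), both with floors within the scatter. Among the compounds with values here, no measured step brings in an aromatic group, so a small lowering is expected rather than a large one.

Compound 4 is therefore estimated at 120000 nM, expected between 40000 nM and 250000 nM. That expectation amounts to a 1.8-fold lower number from compound 3 to compound 4 (0.26 log units; within the scatter).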

Compound 4, solubility: > 250000 nM
Compound 4 gave a limit, no number; the forecaster's own chance of this, stated with the estimate: 10%; middle value at least 2.0-fold (0.31 log units) from the limit.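

Within the data shown here, on this aromatic carbon, benzylamino brings in an aromatic ring for the first time, and in this assay compound 4 gives a limit, not a number. The readable steps are an at least 1.1-fold higher number from compound 3 to compound 4 (0.05 log units; that floor lies within the scatter) and an at least 1.5-fold higher number from compound 2 to compound 4 (0.19 log units; that floor lies within the scatter), so the lowering expected with this ring does not appear, while the step involving compound 1 cannot be read. Compound 1 and compound 4 now sit at the same limit: the limit of > 250000 nM in this assay, at which 2 of the 4 values shown sit.

From the compounds shown here alone, how far apart compound 1 and compound 4 truly lie stays open. So does whether morpholine or a longer chain on this carbon would give a readable number.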